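The source may report more compounds than this note shows. Statements on the series, on what has been measured and on what is new or still open speak of the compounds shown alone.

Measured compounds:
compound 1, `O=C(Nc1cccc(-n2cc(-c3ccncc3)c(-c3ccc(Cl)c(O)c3)n2)c1)Nc1ccc(Cl)c(Cl)c1`, 1500 nM
compound 2, `COc1cc(-c2nn(-c3cccc(NC(=O)Nc4ccc(Cl)c(C(F)(F)F)c4)c3)cc2-c2ccncc2)ccc1Cl`, 1500 nM

Both numbers come from a functional assay on DU-145 cells (Homo sapiens) for inhibition, read by sulforhodamine B assay, with a stated time of 48 h; a higher number here means a weaker inhibitor of growth, a lower number a stronger inhibitor of growth. Compound 2 stands level with compound 1 at the digits shown; the two values lie within the scatter of each other. Compound 1 and compound 2 differ in more than one place, so no single step can be read from this pair; all it shows is that the two readings coincide.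

Compound 3, `O=C(Nc1cccc(-n2cc(-c3ccncc3)c(-c3ccc(Cl)c(O)c3)n2)c1)Nc1ccc(Cl)c(C(F)(F)F)c1`, is not yet measured. It differs from compound 2 in one place: hydrogen in place of methyl on an oxygen on an aromatic ring. Compound 3 therefore carries the hydroxy seen in compound 1 while keeping the rest of compound 2 unchanged. Among the measured compounds shown here, no measured pair isolates this change on its own. In this assay compound 1 with the hydroxy gives 1500 nM and compound 2 with the methoxy gives 1500 nM, so the change in this one position is not expected to move the reading beyond the scatter in either direction. The expected step is no change at the digits printed from compound 2 to compound 3 (within the scatter). Compound 3 is estimated at 1500 nM, with a range from 700 nM to 3500 nM.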

Compound 3, concentration for 50% growth inhibition: 1130 nM
For compound 3 the middle estimate is 1.3-fold (0.12 log units) above the measured one, within the range that was stated.
By their numbers in this assay, from the lowest: compounds 3, 1 and 2 (each within the scatter of the next).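

In this assay, the change from methoxy to hydroxy on the 4-chloro-3-substituted phenyl can now be read on its own, with the rest of the molecule held fixed: it gives a 1.3-fold lower number from compound 2 to compound 3 (0.12 log units; within the scatter), so the two groups on this oxygen-bearing aromatic carbon cannot be told apart in this read-out. Among the compounds shown here, the earlier pair differed in more than one place, and its coinciding values could have hidden two opposing steps; the second single change, trifluoromethyl in place of chloro on an aromatic carbon, gives a 1.3-fold lower number from compound 1 to compound 3 (0.12 log units; within the scatter), so neither single step lies beyond the scatter and no opposing steps are seen. Nothing independent of these growth readings bears on either step.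

The compounds shown cover only hydrogen and methyl on this oxygen and only chloro and trifluoromethyl at the other site, so the reading for an ethoxy group or an amine in place of the hydroxy stays open. On these data alone, whether a carboxylic acid or a longer chain at either place would move the number beyond the scatter also stays open.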